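The compounds below may be only part of what the source reports. "The series", "measured", "known", "first", "only" and "open" are said of these compounds alone.

Measured so far:
Compound 1 `N#Cc1ccc(/C=C/C(=O)c2cc(O)c(O)c([N+](=O)[O-])c2)cc1`: in an assay for inhibition of Catechol O-methyltransferase (Rattus norvegicus), read by fluorescence and spectrophotometry (a lower number here means a stronger inhibitor, a higher number a weaker inhibitor), compound 1 gives 180 nM.
Compound 2 `CC(=O)N1N=C(c2cc(O)c(O)c([N+](=O)[O-])c2)CC1c1nccs1`: in this assay compound 2 gives 160 nM.
Compound 3 `N#Cc1cccc(/C=C/C(=O)c2cc(O)c(O)c([N+](=O)[O-])c2)c1`: in this assay compound 3 gives 240 nM.

All three compounds keep the same shared core and differ in what is attached to it. On the numbers shown, compound 2 sits with the other two inside the usual scatter: its nearest neighbour is compound 1 and its furthest is compound 3, and neither gap is beyond what repeated measurement would give. Among the measured compounds shown here, no single-point step between measured compounds is available, so the series offers no direct calibration of any one change.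

The compound still to be measured is compound 4 `CC(=O)N1N=C(c2cc(O)c(O)c([N+](=O)[O-])c2)CC1c1cccc(C#N)c1`. Relative to compound 2 the change is 3-cyanophenyl in place of 1,3-thiazol-2-yl on a saturated ring carbon. For the measured compounds named here, the only guidance is indirect: compounds 1 and 3 both carry a cyanophenyl group, on a different core, and their values in this assay fall within the scatter of the value of compound 2. Nothing in these three numbers points to a step in either direction beyond the scatter.

The expectation for compound 4 is therefore a value close to that of compound 2, estimated at 190 nM with a range of 80 nM to 450 nM. The step this estimate implies, a 1.2-fold higher number from compound 2 to compound 4 (0.07 log units; within the scatter), is expected to stay within the scatter.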

Compound 4, half-maximal inhibitory concentration: 79 nM
Estimate against measurement, compound 4: 2.4-fold (0.38 log units) above; measured number outside the range, below it.
By their numbers in this assay, from the lowest: compound 4; then compounds 2, 1 and 3 (each within the scatter of the next).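

Among the compounds shown here, on the saturated ring carbon, 3-cyanophenyl in place of 1,3-thiazol-2-yl provides the first single-place comparison: in this assay, the change gives a 2.0-fold lower number from compound 2 to compound 4 (0.31 log units; beyond the scatter). This position therefore accepts a six-membered aromatic ring of carbon only, bearing a nitrile, in place of the five-membered aromatic ring with two hetero atoms, and the inhibitor number does not rise. No measurement shown accounts for this step, and this single pair cannot separate the contribution of the ring from that of the nitrile.

The compounds shown leave open whether the step needs the nitrile at all, since an unsubstituted phenyl group at this position would be required to separate the ring from its substituent, and an aminomethyl or carboxylic acid group in place of the nitrile would test how specific that substituent is. Also open, as far as these compounds go, is whether the step carries over when the acetyl group on the ring nitrogen is replaced by a longer acyl chain, and the cyanophenyl compounds on the other core offer no direct comparison with compound 4.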